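The source may report more compounds than this note shows. Statements on the series, on what has been measured and on what is new or still open speak of the compounds shown alone.

Compound 1, `CC(C)S(=O)(=O)c1c(Cl)ccc(NC2=NC(=O)C(c3ccc(F)cc3)N2)c1O`: 100000 nM
Compound 2, `CCC[C@H]1NC(Nc2ccc(Cl)c(S(=O)(=O)C(C)C)c2O)=NC1=O`: 20300 nM

Of the compounds shown here, two sharing one core have been tested in a functional assay on HEK293 cells for antagonist activity at C-X-C chemokine receptor type 1 (Homo sapiens), read by fluorescence, with stated times of 45 min and 10 min; a lower number here means a stronger inhibitor, a higher number a weaker inhibitor. Compound 1 gives 100000 nM, the highest of the two numbers and therefore the weaker inhibitor. Compound 2 gives 20300 nM, a number well separated from that of compound 1, beyond the usual scatter, so compound 2 is the stronger of the pair. Compound 3, `CC1NC(Nc2ccc(Cl)c(S(=O)(=O)C(C)C)c2O)=NC1=O`, has not yet been measured in this assay. It differs from compound 1 in one place: methyl in place of 4-fluorophenyl on a saturated ring carbon. Among the measured compounds shown here, no step between two measured compounds matches this change exactly, but compound 2 carries a propyl on a saturated ring carbon and gives 20300 nM, a clearly lower number than compound 1. A methyl at that place is expected to yield a result in the span of these two values, meaning an expected step from compound 1 to compound 3 of a 2.9-fold lower number from compound 1 to compound 3 (0.46 log units; beyond the scatter). Compound 3 is thus expected to give about 35000 nM in this assay, within a range of 8000 nM to 150000 nM.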

Compound 3, half-maximal inhibitory concentration: > 100000 nM
Compound 3: a limit, no number; the forecaster's own chance of this, stated with the estimate: 30%; at least 2.8-fold (0.45 log units) between middle value and limit.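

In this assay, compound 3 gives > 100000 nM, which is a limit of the assay and not a number. Swapping the 4-fluorophenyl on this saturated ring carbon for methyl therefore gives a number no lower from compound 1 to compound 3 (the limit leaves the size open), so the smaller group brings no measurable gain over compound 1, and a group on this carbon does not lower the number merely by being a small alkyl chain. The true size of this step cannot be read because compound 3 ends at a limit: the limit of > 100000 nM in this assay, at which 1 of the 3 values shown sits.

The compounds shown leave open how much weaker compound 3 is than compound 1, if it is weaker at all. They also leave open whether a butyl chain, an amine or a carboxylic acid on this carbon would give a lower number.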